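Adding One More Methoxy Group to Compound 2

This account rests on a few compounds, and the source may have more. Where it says the series, first, only, none or still open, it means among the compounds named here.

Compound 1 (`C=C(Br)C(=O)Nc1ccc(C(=O)/C=C/c2ccc(OC)c(OC)c2)cc1`) and compound 2 (`C=C(Br)C(=O)Nc1ccc(C(=O)/C=C/c2ccc(OC)cc2OC)cc1`) share a core and differ only in where their methoxy groups sit. In a functional assay on MOLT-4 cells (Homo sapiens) for antiproliferative activity, with a stated time of 48 h (on this read-out lower numbers stand for stronger inhibition and higher numbers for weaker inhibition), compound 1 gives 1800 nM and compound 2 gives 1500 nM. These two numbers lie within the usual scatter of repeated measurements, so neither compound can be ranked over the other. Compound 3 (`C=C(Br)C(=O)Nc1ccc(C(=O)/C=C/c2ccc(OC)c(OC)c2OC)cc1`) takes compound 2 one step further: methoxy in place of hydrogen on an aromatic carbon, with methoxy in place of hydrogen on an aromatic carbon, ortho to two methoxy groups. For the measured compounds named here, no measured pair yet shows what such an addition does in this assay. Going by the values given here, the only guide is compound 2 itself at 1500 nM, so no step beyond the scatter is expected. The estimated change, a 1.2-fold lower number from compound 2 to compound 3 (0.06 log units; within the scatter), is small and could go either way. For compound 3 the expected value is 1300 nM, within a range of 550 nM to 3000 nM.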

Compound 3, half-maximal inhibitory concentration: 680 nM
Compound 3: middle estimate off by 1.9-fold (0.28 log units), on the high side, and the stated range covers the measured number.
By their numbers in this assay, from the lowest: compound 3; then compounds 2 and 1 (each within the scatter of the next).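

Putting a methoxy group in place of hydrogen on this aromatic carbon, ortho to two methoxy groups, produces the first difference in this assay that clearly exceeds the scatter: a 2.2-fold lower number from compound 2 to compound 3 (0.34 log units; beyond the scatter) is a modest but readable change. The same comparison starting from the other earlier compound shows a 2.6-fold lower number from compound 1 to compound 3 (0.42 log units; beyond the scatter) and points the same way, so compound 3 stands apart from both, even though compound 1 and compound 2 cannot be ranked against each other. No measurement at hand explains this difference.

On these data alone, whether a hydroxyl group, a fluorine atom or an amine on this carbon would lower the number as well remains open. Also open, as far as these compounds go, is whether the lower number requires all three methoxy groups together.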